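Dropping the Amino Group from Compound 1

The source may report more compounds than this note shows. Statements on the series, on what has been measured and on what is new or still open speak of the compounds shown alone.

This account follows a pyrrolidine urea series through a physicochemical assay for solubility, measured as kinetic solubility; a higher number here means a more soluble compound, a lower number a less soluble compound. Three members have been measured. Compound 1, `Nc1nccc(N2CC[C@H](NC(=O)Nc3ccc(Cl)c(C(F)(F)F)c3)C2)n1`, gives 30300 nM in this assay. Compound 2, `CNc1nccc(N2CC[C@H](NC(=O)Nc3ccc(OC(F)F)cc3)C2)n1`, gives 92800 nM, and compound 3, `CNc1nccc(N2CC[C@H](NC(=O)Nc3ccc(CN4CCN(C)CC4)c(C(F)(F)F)c3)C2)n1`, gives 67500 nM. Among the three, compound 1 stands lowest: the nearest number is that of compound 3, which lies beyond the usual scatter, and the furthest is that of compound 2, also beyond it. Within the data shown here, no pair of these measured compounds differs in only one place, so no single-point step can be read from them directly.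

The step now taken leads from compound 1 to compound 4, `O=C(Nc1ccc(Cl)c(C(F)(F)F)c1)N[C@H]1CCN(c2ccncn2)C1`, which has not yet been measured in this assay. The change is hydrogen in place of amino on an aromatic carbon, on an aromatic carbon of a six-membered aromatic ring with two nitrogen atoms, between two ring nitrogen atoms; cut one bond further out, it reads as 2-aminopyrimidin-4-yl becoming pyrimidin-4-yl. Among the measured compounds shown here, since no measured pair shows this step, only an expectation can be offered.

The loss of one hydrogen-bond donor and one hydrogen-bond acceptor is expected to move the number downward by a modest step, a 1.5-fold lower number from compound 1 to compound 4 (0.18 log units; within the scatter), near the edge of the scatter. Compound 4 is therefore estimated at 20000 nM, in a range from 7000 nM to 50000 nM.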

Compound 4, solubility: 2400 nM
The estimate for compound 4 lay 8.3-fold (0.92 log units) above the measured number; measured number below the stated range.
By their numbers in this assay, from the lowest: compound 4; then compound 1; then compounds 3 and 2 (each within the scatter of the next).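

In this assay, the amino group on the aromatic carbon between two ring nitrogen atoms proves to be no minor detail, as hydrogen in its place gives a 13-fold lower number from compound 1 to compound 4 (1.10 log units; beyond the scatter), a large step well beyond the scatter. Among these compounds, this is the first step that can be read at a single place, and it shows that this one position, with the rest of compound 1 unchanged, is enough to move the number strongly and to leave compound 4 lowest of the four. Nothing at hand gives a measured reason for the size of this step.

The compounds shown leave open whether the number depends on the amino group itself or on the presence of any group at this carbon, a question that a methyl group, a hydroxyl group or a dimethylamino group there would address, since the single step removes one hydrogen-bond donor and one hydrogen-bond acceptor together and cannot separate them. They also leave open whether a step of this size would recur with the other aryl ureas in the series, such as the ones carried by compound 2 and compound 3.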